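The compounds below may be only part of what the source reports. "The series", "measured", "known", "first", "only" and "open" are said of these compounds alone.

Measured in an assay on HEK293 cells for agonist activity at Toll-like receptor 8 (Homo sapiens); on this read-out higher numbers stand for an effect only at larger amounts of compound and lower numbers for an effect already at smaller amounts:
compound 1 `CCC[C@@H](CO)Nc1nc(N)nc(C)c1Cc1ccc(CNCCO)cc1OC`, 5370 nM
compound 2 `CCC[C@@H](CCO)Nc1nc(N)nc(C)c1Cc1ccc(CNCCC(N)=O)cc1OC`, > 10000 nM, a limit of the assay
compound 3 `CCC[C@@H](CCO)Nc1nc(N)nc(C)c1Cc1ccc(CNCCO)cc1OC`, > 10000 nM, a limit of the assay

Within the data shown here, compound 1 carries the only number in this assay; the two other values sit at the limit of > 10000 nM in this assay, at which 2 of the 3 values shown sit. The step of an at least 1.8-fold higher number from compound 1 to compound 3 (0.27 log units; that floor lies within the scatter) runs from that number to a limit, so its true size is open. The step that the two limits leave unreadable from compound 2 to compound 3 joins two limits and cannot be sized at all.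

Compound 4 `CCC[C@@H](CO)Nc1nc(N)nc(C)c1Cc1ccc(CNC2CN(C)C2)cc1OC` differs from compound 1 by 1-methylazetidin-3-yl in place of 2-hydroxyethyl on an amine nitrogen. Neither measured step touches the amine nitrogen in this way: one alters the hydroxy-bearing chain on the ring nitrogen, the other swaps hydroxy for carbamoyl two bonds from the amine nitrogen, and both end at a limit. Nothing measured therefore gives a direction for this change, and the expectation is a step of a 1.2-fold lower number from compound 1 to compound 4 (0.08 log units; within the scatter) that stays close to compound 1. Compound 4 is estimated at 4500 nM in this assay, expected between 1200 nM and 16000 nM.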

Compound 4, half-maximal effective concentration: 6170 nM
The estimate for compound 4 lay 1.4-fold (0.14 log units) below the measured number; measured number inside the range.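

In this assay, 1-methylazetidin-3-yl in place of 2-hydroxyethyl on the amine nitrogen gives a 1.1-fold higher number from compound 1 to compound 4 (0.06 log units; within the scatter). Among these compounds, on the core of compound 1, this amine nitrogen therefore accepts the four-membered ring with its ring nitrogen, and loses the hydroxy group with its hydrogen-bond donor, without the number moving beyond the scatter, which is the first readable result for a change at this place. The one earlier step at this amine nitrogen joins compound 2 and compound 3, both limits of the assay and not numbers, and it cannot be read: the limit of > 10000 nM in this assay, at which 2 of the 4 values shown sit.

As far as these compounds go, whether a carboxylic acid, a primary amine or a longer chain on this amine nitrogen would shift the number stays open. Also open, from the compounds shown here alone, is whether any group here takes the number beyond the scatter of compound 1 in either direction.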